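The source may hold more compounds than are shown below. What is called first, only, known or untested is meant among the compounds shown, and "the series" means these compounds.

Measured compounds in the series:
- compound 1, `CCN(CC)S(=O)(=O)c1ccc(S(=O)(=O)N2CCC[C@@H](C(=O)N3CCC(OC)CC3)C2)cc1`: 140 nM
- compound 2, `CCN(CC)S(=O)(=O)c1ccc(S(=O)(=O)N2CCC[C@@H](C(=O)N3CCOCC3)C2)cc1`: 350 nM
- compound 3, `CCN(CC)S(=O)(=O)c1ccc(S(=O)(=O)N2CCC[C@@H](C(=O)N3CCC(F)(F)CC3)C2)cc1`: 16 nM

All three numbers come from a functional assay on MIA PaCa-2 cells (Homo sapiens) for inhibition, read by MTT assay, with a stated time of 7 days; on this read-out lower numbers stand for stronger inhibition and higher numbers for weaker inhibition. Compound 3 gives the lowest number of the three; the step of an 8.8-fold lower number from compound 1 to compound 3 (0.94 log units; beyond the scatter) and the step of a 22-fold lower number from compound 2 to compound 3 (1.34 log units; beyond the scatter) both lie beyond the scatter, so compound 3 stands clearly apart from compound 1 and compound 2.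

Compound 4, `CCN(CC)S(=O)(=O)c1ccc(S(=O)(=O)N2CCC[C@@H](C(=O)N3CC[C@@H](OC)C3)C2)cc1`, is not yet measured. Its change from compound 3 is 3-methoxypyrrolidin-1-yl in place of 4,4-difluoropiperidin-1-yl on a carbonyl carbon. The step that bears on it most directly is an 8.8-fold lower number from compound 1 to compound 3 (0.94 log units; beyond the scatter), read in reverse, since compound 1 also carries a methoxy-substituted saturated ring on the carbonyl carbon; the step of a 22-fold lower number from compound 2 to compound 3 (1.34 log units; beyond the scatter) points the same way. Among the compounds with values here, no measured pair covers the contraction from a six-membered to a five-membered ring, so the expectation rests on the methoxy-for-difluoro exchange alone. A higher number is therefore expected for compound 4 in this assay, of a size near a 9.4-fold higher number from compound 3 to compound 4 (0.97 log units; beyond the scatter), with a wide range. Compound 4 is estimated at 150 nM, between 50 nM and 500 nM.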

Compound 4, half-maximal inhibitory concentration: 3910 nM
For compound 4 the middle estimate is 26-fold (1.42 log units) below the measured one, outside the stated range (above it).
By their numbers in this assay, from the lowest: compound 3; then compound 1; then compound 2; then compound 4.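

In this assay, the substituent on the carbonyl carbon has a far wider range than the six-membered amines alone showed: a 240-fold higher number from compound 3 to compound 4 (2.39 log units; beyond the scatter) makes compound 4 the weakest of the series. The methoxy-for-difluoro exchange does not describe the whole change, since a 28-fold higher number from compound 1 to compound 4 (1.45 log units; beyond the scatter) separates two methoxy-bearing amides. The 3-methoxypyrrolidin-1-yl group also falls behind the unsubstituted morpholin-4-yl group, with an 11-fold higher number from compound 2 to compound 4 (1.05 log units; beyond the scatter) in the same assay.

The compounds shown do not separate the five-membered ring from the place of the methoxy group or from the defined stereocentre. Unsubstituted pyrrolidin-1-yl and 3,3-difluoropyrrolidin-1-yl on the same carbonyl carbon remain open as the comparisons that would address this.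

No supporting data bear on the reason for the size of these steps.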